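The source may hold more compounds than are shown below. What is called first, only, known or untested is meant among the compounds shown, and "the series" means these compounds.

Of the compounds shown here, three have so far been read in a functional assay (Homo sapiens) for inhibition; a lower number here means a stronger inhibitor, a higher number a weaker inhibitor. There, compound 1 `CCCCCCc1cc(/C=C/C(=O)c2ccc(O)cc2)c(OC)cc1O` gives 46000 nM, compound 2 `O=C(/C=C/c1ccc(Oc2ccccc2)cc1)c1ccc(F)cc1` gives 33000 nM, and compound 3 `O=C(/C=C/c1ccc([N+](=O)[O-])cc1)c1ccc([N+](=O)[O-])cc1` gives 51000 nM. Compound 2 has the lowest number of the three, but its gaps to both others lie within the scatter, so it stands level with them and no ranking can be drawn. No two of these compounds differ in only one place, so no measured step is available as a guide.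

Compound 4 `O=C(/C=C/c1ccc(F)cc1)c1ccc(F)cc1` departs from compound 2 in a single place, with fluoro in place of phenoxy on an aromatic carbon. The change is large in counted terms, yet the structurally varied compound 1 at 46000 nM and compound 3 at 51000 nM sit level with compound 2, so no shift beyond the scatter is expected in this assay. The expected step of a 1.2-fold higher number from compound 2 to compound 4 (0.08 log units; within the scatter) is therefore small. For compound 4 the estimated value is 40000 nM, with an expected range from 15000 nM to 100000 nM.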

Compound 4, half-maximal inhibitory concentration: 22000 nM
For compound 4 the middle estimate is 1.8-fold (0.26 log units) above the measured one; the range from low to high includes it.
By their numbers in this assay, from the lowest: compounds 4, 2, 1 and 3 (each within the scatter of the next, the first and the last beyond it).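

Fluoro in place of phenoxy on an aromatic carbon, para to a large group, gives a 1.5-fold lower number from compound 2 to compound 4 (0.18 log units; within the scatter) in this assay, so the two compounds stand level. Going by these compounds alone, this is the first measured step at this position, and it shows that in this pair, removing phenoxy, with its six-membered aromatic ring of carbon only and its hydrogen-bond acceptor, moves the number by no more than the scatter. The data shown offer no measurement that could explain this result.

On these data alone, it remains open whether another group at this position, such as an amine, a carboxylic acid or a longer chain, would move the number beyond the scatter. Also open is whether the fluoro shared by compound 2 and compound 4 matters, as no compound shown changes it alone.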